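The source may report more compounds than this note shows. Statements on the series, on what has been measured and on what is new or still open speak of the compounds shown alone.

Measured in a functional assay on HepG2 cells (Homo sapiens) for cytotoxicity, read by MTT assay, with a stated time of 48 h; a lower number here means a stronger inhibitor, a higher number a weaker inhibitor:
Compound 1 `COc1cc(/C=C/C(=O)/C=C(/C=C/c2ccc(O)c(OC)c2)NCCO)ccc1O`: > 100000 nM, a limit of the assay
Compound 2 `COc1cc(/C=C/C(=O)/C=C(/C=C/c2ccc(O)c(OC)c2)NCCCO)ccc1O`: > 100000 nM, a limit of the assay

Compound 2 has no exact number, and its place is the limit of > 100000 nM in this assay, at which 2 of the 2 values shown sit. The change to compound 3 `COCCNC(=C\C(=O)/C=C/c1ccc(O)c(OC)c1)/C=C/c1ccc(O)c(OC)c1` keeps the same atoms but joins them differently: methoxy in place of hydroxymethyl on a saturated chain carbon, two bonds along the chain from an amine nitrogen. In words, this is methoxy in place of hydroxymethyl on a saturated chain carbon, two bonds along the chain from an amine nitrogen.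

Among the measured compounds shown here, the only measured step at this place is a step that the two limits leave unreadable from compound 1 to compound 2, which gives no size to carry over. Resting on that step, no change beyond the scatter is expected in this assay, in either direction, and the assay may again report only a limit. For compound 3 the estimated value is 100000 nM, with an expected range of 40000 nM to 250000 nM. This estimate implies an expected a number no higher from compound 2 to compound 3 (the limit leaves the size open).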

Compound 3, half-maximal inhibitory concentration: > 100000 nM
Compound 3: no number, only a limit; the forecaster's own chance of this, stated with the estimate: 80%; the middle value sits exactly at the limit.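

In this assay compound 3 gives > 100000 nM, which is a limit of the assay. Among the compounds shown here, no step among compound 1, compound 2 and compound 3 can be read. The compounds shown leave open whether changing the chain on the amine nitrogen shifts the value in this assay at all, since none of the three has an exact number.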